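Base change on the core of compound 2

A few compounds are considered here, and "the series" means these few. Any claim that something is new, unique, unknown or untested is made for them only; others in the source may bear on it.

Measured so far in this series:
compound 1, `Nc1ncn(C/C=C2\OC(=O)C(OCc3ccccc3)=C2OCc2ccccc2)c(=O)n1`, gives 4670 nM
compound 2, `NC1(CCn2ncc(=O)[nH]c2=O)OC(=O)C(OCc2ccccc2)=C1OCc1ccccc1`, gives > 100000 nM
compound 3, `O=C1O[C@H]([C@@H](O)Cn2ccc(NC(=O)c3ccccc3)nc2=O)C(OCc2ccccc2)=C1OCc1ccccc1`, gives 8820 nM

In an ADME assay on WI-38 cells (Homo sapiens) for inhibition, read by MTT assay, with a stated time of 72 h (on this read-out lower numbers stand for stronger inhibition and higher numbers for weaker inhibition), compound 2 returns only a limit, > 100000 nM, and not a number; this is the limit of > 100000 nM in this assay, at which 1 of the 3 values shown sits. Compound 1 and compound 3 return numbers in the same read-out. Compound 4, `Nc1ccn(CCC2(N)OC(=O)C(OCc3ccccc3)=C2OCc2ccccc2)c(=O)n1`, differs from compound 2 by a group of 8 heavy atoms (4 carbon, 3 nitrogen, 1 oxygen; one six-membered aromatic ring with 2 hetero atoms) in place of a group of 8 heavy atoms (3 carbon, 3 nitrogen, 2 oxygen; one six-membered aromatic ring with 3 hetero atoms), on a saturated chain carbon, two bonds along the chain from a saturated ring carbon. Among the measured compounds shown here, no measured pair isolates this change, so its size is not known from the data. Since compound 2 sits at a limit, only a direction toward a measurable number is expected for compound 4, not a quantified step. The estimate for compound 4 is 30000 nM, range 8000 nM to 100000 nM. The step this estimate implies, an at least 3.3-fold lower number from compound 2 to compound 4 (0.52 log units; beyond the scatter), is expected rather than measured.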

Compound 4, half-maximal inhibitory concentration: 88900 nM
Beside the measured number, compound 4's estimate is 3.0-fold (0.47 log units) below it, and the stated range covers the measured number.
By their numbers in this assay, from the lowest: compounds 1 and 3 (each within the scatter of the next); then compound 4. At a limit, above all of these: compound 2.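

Compound 2 returns only a limit in this assay: the limit of > 100000 nM in this assay, at which 1 of the 4 values shown sits.

With the six-membered aromatic ring with 2 hetero atoms on the saturated chain carbon, compound 4 gives a measured number, the first on this core. From the compounds shown here alone, the change reads as an at least 1.1-fold lower number from compound 2 to compound 4 (0.05 log units; that floor lies within the scatter), so its true size remains unknown and its floor shows no change beyond the scatter.

Open, going by these compounds, is how a longer chain at this place, or a methyl group on the entering ring, would read in this assay.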